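Anilinomethyl for Trifluoromethyl: Expected Mouse Microsomal Stability

A few compounds are considered here, and "the series" means these few. Any claim that something is new, unique, unknown or untested is made for them only; others in the source may bear on it.

Measured compounds:
compound 1 `CCOc1ccccc1-c1ccc(CO[C@@H]2COc3nc([N+](=O)[O-])cn3C2)cc1`: 0.2%
compound 2 `O=[N+]([O-])c1cn2c(n1)OC[C@@H](OCc1ccc(-c3cccc(OCc4ccccc4)c3)cc1)C2`: 50%
compound 3 `O=[N+]([O-])c1cn2c(n1)OC[C@@H](OCc1ccc(-c3ccc(C(F)(F)F)cc3)cc1)C2`: 85%

Three compounds sharing one core were tested in an ADME assay on microsomes from liver (Mus musculus, strain CD1) for metabolic stability, read by LC-MS, with a stated time of 1 h; on this read-out higher numbers stand for a more stable compound and lower numbers for a less stable compound. Compound 3 stands highest of the three: compound 2 lies nearest to it, and compound 1 lies furthest away, both separated from it beyond the scatter. Among the compounds with values here, the single one-place step measured so far, a number 84.8 percentage points higher from compound 1 to compound 3 (beyond the scatter), shows how strongly the group on the outer aromatic ring governs this read-out.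

Compound 4 `O=[N+]([O-])c1cn2c(n1)OC[C@@H](OCc1ccc(-c3ccc(CNc4ccccc4)cc3)cc1)C2` carries the change (anilinomethyl in place of trifluoromethyl on an aromatic carbon). Within the data shown here, no measured step covers this exact exchange. What is known is that compound 3, with trifluoromethyl, sits far above the other substitution patterns seen, and that compound 2, whose outer ring carries the larger benzyloxy group, reaches only 50%. On that basis compound 4 is expected to fall clearly below compound 3, with a step of a number 65 percentage points lower from compound 3 to compound 4 (beyond the scatter) in this assay. The estimate for compound 4 is 20%, with a range from 3% to 55%.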

Compound 4, percent of the compound remaining: 52%
The estimate for compound 4 lay 32 percentage points below the measured number, and the stated range covers the measured number.
By their numbers in this assay, from the lowest: compound 1; then compounds 2 and 4 (each within the scatter of the next); then compound 3.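

At this aromatic carbon, para to a large group, putting anilinomethyl in place of trifluoromethyl gives a number 33 percentage points lower from compound 3 to compound 4 (beyond the scatter) in this assay. The earlier compounds shown here showed no exchange at this place, and this step shows that the number here responds to the group chosen, although compound 4, with a much larger group carrying a six-membered aromatic ring and a hydrogen-bond donor, still gives 52% and is not lost from the read-out. No supporting measurement bears on why the number moves with this exchange.

The compounds shown leave open which part of anilinomethyl goes with the step, the aromatic ring or the amine nitrogen linking it. As far as these compounds go, how a plain aminomethyl group, a carboxylic acid or a simple methyl group would read at this same place also remains open.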